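Pentylamino to butyl on the shared core: an expected step

The source may hold more compounds than are shown below. What is called first, only, known or untested is meant among the compounds shown, and "the series" means these compounds.

Measured so far, in a functional assay (spleen, spleen) for activation, with Mus musculus as the target; on this read-out lower numbers stand for an effect already at smaller amounts and higher numbers for an effect only at larger amounts of compound:
compound 1 `CCCCCNc1nc(N)c2nc(O)n(Cc3ccccc3)c2n1` gives 0.1 uM
compound 2 `Nc1ncnc2c1nc(Cl)n2Cc1ccccc1` reaches only the limit > 10 uM
compound 3 `COc1cccc(Cn2c(O)nc3c(N)ncnc32)c1` gives 10 uM

Compound 1 holds the lowest of the two numbers. Its nearest neighbour is compound 3, whose number is higher by a gap that lies beyond the scatter. For compound 2 the result is a limit of this assay and not a number, as noted in the limit of > 10 uM in this assay, at which 1 of the 3 values shown sits.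

Compound 4 `CCCCc1nc(N)c2nc(O)n(Cc3ccccc3)c2n1` differs from compound 1 in one place: butyl in place of pentylamino on an aromatic carbon. No step between two measured compounds is shown, so the size of this change cannot be read from a measured pair. The account treats the loss of the hydrogen-bond donor and acceptor of the pentylamino as likely to cost some effect, though perhaps not far beyond the scatter. For compound 4 the estimated result in this assay is 0.3 uM, with a range from 0.03 uM to 3 uM. The expected step of a 3.0-fold higher number from compound 1 to compound 4 (0.48 log units; beyond the scatter) is a modest rise in the number.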

Compound 4, minimum effective concentration: 0.03 uM
The estimate for compound 4 lay 10-fold (1.00 log units) above the measured number; low and high end bracket the measured number.
By their numbers in this assay, from the lowest: compound 4; then compound 1; then compound 3.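

Putting butyl in place of pentylamino on the aromatic carbon between two ring nitrogen atoms gives, in this assay, a 3.3-fold lower number from compound 1 to compound 4 (0.52 log units; beyond the scatter) and so shows that this position tolerates the change. The hydrogen-bond donor and acceptor that leave with the pentylamino are therefore not needed here for an effect at small amounts, and a plain carbon chain serves at this carbon. Nothing in the data shown accounts for the size of this step.

The swap removes the nitrogen and shortens the chain in a single move, so the compounds shown cannot say which of the two carries the step. On these data alone, what a butylamino or a pentyl group gives at this carbon stays open, as does the effect of a longer chain or a carboxylic acid there.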